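Series notes: ethyl replacing aryl on the ring amide nitrogen

The source may hold more compounds than are shown below. What is called first, only, known or untested is meant among the compounds shown, and "the series" means these compounds.

Measured in a functional assay on HOS-TE85 cells (Homo sapiens) for inhibition, read by CCK-8 assay, with a stated time of 72 h; a higher number here means a weaker inhibitor, a lower number a stronger inhibitor:
- compound 1 `O=C(NCCCCc1ccccc1)c1cccc(C2SCC(=O)N2c2cccc(-c3c[nH]nn3)c2)c1`: 110 nM
- compound 2 `CC(C)(C)c1conc1N1C(=O)CSC1c1cccc(C(=O)NCCCCc2ccccc2)c1`: > 1000 nM; this is a limit of the assay, not a number
- compound 3 `O=C(NCCCCc1ccccc1)c1cccc(C2SCC(=O)N2c2cccc(F)c2)c1`: 32.4 nM

Compound 3 gives the lowest of the two numbers shown; its nearest neighbour is compound 1, with a 3.4-fold lower number from compound 1 to compound 3 (0.53 log units; beyond the scatter). For compound 2 the value is only a limit (the limit of > 1000 nM in this assay, at which 1 of the 3 values shown sits). The step of an at least 30-fold lower number from compound 2 to compound 3 (1.48 log units; beyond the scatter) shows that the group on the amide-type nitrogen in the ring strongly affects the number.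

Compound 4 `CCN1C(=O)CSC1c1cccc(C(=O)NCCCCc2ccccc2)c1` is the next variation: ethyl in place of 3-fluorophenyl on an amide-type nitrogen in a ring. Among the compounds with values here, both measured steps touching this position, a 3.4-fold lower number from compound 1 to compound 3 (0.53 log units; beyond the scatter) and an at least 30-fold lower number from compound 2 to compound 3 (1.48 log units; beyond the scatter), moved the number by a modest to large amount when the group on that nitrogen changed, and the 3-fluorophenyl gave the lowest number so far. Removing the aromatic ring in favour of ethyl is therefore expected to raise the number in this assay beyond the scatter, by a 12-fold higher number from compound 3 to compound 4 (1.09 log units; beyond the scatter). For compound 4 the expected value is 400 nM, within 100 nM to 2000 nM.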

Compound 4, half-maximal inhibitory concentration: > 1000 nM
Compound 4 gave a limit, no number; the forecaster's own chance of this, stated with the estimate: 30%; middle value at least 2.5-fold (0.39 log units) away from the limit.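

In this assay, ethyl on the amide-type nitrogen in the ring gives an at least 30-fold higher number from compound 3 to compound 4 (1.48 log units; beyond the scatter), so an aromatic ring at this position now has a direct comparison with a small chain carrying no ring. The triazole-bearing aryl group also compares favourably with ethyl, an at least 9.0-fold higher number from compound 1 to compound 4 (0.95 log units; beyond the scatter), and among the four compounds only those with a six-membered aromatic ring of carbon on this nitrogen give a number rather than a limit. Compound 2 and compound 4 each give a limit, so the step between them cannot be read: the limit of > 1000 nM in this assay, at which 2 of the 4 values shown sit.

As far as these compounds go, whether the 3-fluorophenyl group owes its low number to the ring alone or also to the fluoro remains open, and unsubstituted phenyl would address this. Also open, from the compounds shown here alone, is whether benzyl or a longer chain such as n-hexyl behaves like ethyl or like the aryl groups.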